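Amide nitrogen substituent swap on two related cores

This account rests on a few compounds, and the source may have more. Where it says the series, first, only, none or still open, it means among the compounds named here.

Measured so far:
Compound 1 `O=C(/C=C1\CCc2cc(Cl)ccc21)NC1CC1` gives 17% in a functional assay on the whole organism with Mus musculus as the target, at a dose of 100 mg/kg by the intraperitoneal route; a higher number here means more inhibition at the dose given (going by the name of the read-out), a lower number less inhibition.
Compound 2 `O=C(/C=C1\CCc2cc(F)cc(F)c21)NC1CC1` gives 100% in this assay.
Compound 3 `CNC(=O)/C=C1\CCc2cc(F)cc(F)c21` gives 33% in this assay.

Compounds 2 and 3 share one core and differ only at the amide: methyl in place of cyclopropyl on an amide-type nitrogen. In this assay this gives a number 67 percentage points lower from compound 2 to compound 3 (beyond the scatter), a large step.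

Compound 1 carries a different core; how the core of compound 1 and the core of compound 2 differ is not broken down here. In this assay compound 1 stands lowest of the three, beyond the scatter from both compound 3 and compound 2.

Compound 4 `CNC(=O)/C=C1\CCc2cc(Cl)ccc21` is not yet measured. It differs from compound 1 by methyl in place of cyclopropyl on an amide-type nitrogen. Going by the values given here, the place of the change is described in the same words for both pairs, so this is the same change as the one from compound 2 to compound 3, now made on the core of compound 1.

Among the compounds with values here, the only precedent for this change is the large drop from compound 2 to compound 3. Compound 1, however, starts at 17%, which leaves little room below it, and the read-out cannot fall much further. So for compound 4 a smaller step is expected, a number 12 percentage points lower from compound 1 to compound 4 (beyond the scatter). Compound 4 is therefore expected to give about 5% in this assay, estimated to lie between 0% and 20%.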

Compound 4, a percentage reported as inhibition, in the whole organism at one dose (the size of the read-out at that dose, not a potency): 50%
Compound 4: middle estimate off by 45 percentage points, on the low side, outside the stated range (above it).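

In this assay, methyl in place of cyclopropyl on the amide-type nitrogen of the core of compound 1 gives a number 33 percentage points higher from compound 1 to compound 4 (beyond the scatter), a large step. Going by these compounds alone, the same change therefore does not carry from one core to the other, in size or in direction, and its outcome here depends on the core that bears it: the same change on two cores in this assay, a number 67 percentage points lower (beyond the scatter) from compound 2 to compound 3 and a number 33 percentage points higher (beyond the scatter) from compound 1 to compound 4, 100 percentage points apart, beyond the scatter of two such steps This rests on only two matched pairs at a single dose, so it shows neither why the sign reverses nor how the change would behave on any further core, and as the read-out is the size of the inhibition at that dose, it says nothing about potency.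

The compounds shown leave open how other groups on the same nitrogen, such as ethyl, isopropyl or cyclobutyl, or the amide hydrogen alone in place of any such group, would place themselves relative to cyclopropyl and methyl on each of the two cores. Within the data shown here, they also leave open which part of the difference between the core of compound 1 and the core of compound 2 goes with the reversal, and a compound changed in only one place of the core would be needed to separate that.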